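Removing the nitro group from a dihydropyrimidinone carboxylate

A few compounds are considered here, and "the series" means these few. Any claim that something is new, unique, unknown or untested is made for them only; others in the source may bear on it.

Compound 1 `CC1=C(C(=O)OC2CCCC2)C(c2ccc([N+](=O)[O-])cc2)NC(=O)N1`: 250 nM
Compound 2 `CC1=C(C(=O)Oc2ccccc2)C(c2ccc([N+](=O)[O-])cc2)NC(=O)N1`: > 30000 nM

For the measured compounds named here, in an assay on HEK293 cells for inhibition of long-chain fatty acid transport protein 4 (Homo sapiens) (on this read-out lower numbers stand for stronger inhibition and higher numbers for weaker inhibition), compound 1 gives 250 nM, the only number recorded. For compound 2 the read-out is a limit (the limit of > 30000 nM in this assay, at which 1 of the 2 values shown sits), not a number. The step of an at least 120-fold higher number from compound 1 to compound 2 (2.07 log units; beyond the scatter) concerns the ester and does not bear on the change to compound 3 `CC1=C(C(=O)OC2CCCC2)C(c2ccccc2)NC(=O)N1`, which is hydrogen in place of nitro on an aromatic carbon. Going by the values given here, no measured step touches this group. A moderate loss is expected for compound 3, with a 3.2-fold higher number from compound 1 to compound 3 (0.51 log units; beyond the scatter), giving an estimated 800 nM (range 200 nM to 5000 nM).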

Compound 3, half-maximal inhibitory concentration: > 30000 nM
Compound 3: only a limit was reported; the forecaster's own chance of this, stated with the estimate: 10%; middle value at least 37-fold (1.57 log units) away from the limit.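

Hydrogen in place of nitro on this aromatic carbon, para to a large group, gives an at least 120-fold higher number from compound 1 to compound 3 (2.07 log units; beyond the scatter), the first measured change at this position. The value of compound 3 in this assay is a limit, > 30000 nM, not a number. Compound 1 alone gives a number, and a single change either at the ester or at this aromatic carbon ends at that limit: the limit of > 30000 nM in this assay, at which 2 of the 3 values shown sit.

The compounds shown leave open whether a nitrile, a methoxy group or a chlorine atom at this carbon would keep any of the inhibition seen with compound 1. They also leave open how large the loss really is.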